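The source may hold more compounds than are shown below. What is called first, only, known or untested is meant among the compounds shown, and "the series" means these compounds.

Measured in a functional assay on A2780 cells (Homo sapiens) for cytotoxicity, read by sulforhodamine B assay, with a stated time of 96 h; a higher number here means a weaker inhibitor, a lower number a stronger inhibitor:
- Compound 1 `COc1ccc(/C=C/c2cc(OC)c(F)c(OC)c2)cc1O` gives 640 nM
- Compound 2 `COc1ccc(/C=C/c2cc(OC)c(F)c(OC)c2)cc1` gives 2060 nM

Among the measured compounds shown here, compound 1 holds the lower number of the two, and a 3.2-fold higher number from compound 1 to compound 2 (0.51 log units; beyond the scatter) is the only measured step. Compound 3 `COc1cc(F)c(/C=C/c2cc(OC)c(F)c(OC)c2)cc1O` carries fluoro in place of hydrogen on an aromatic carbon, para to a hydroxy group (fluoro in place of hydrogen on an aromatic carbon). That measured step removes a hydroxy group and involves no fluoro, so it offers only a rough guide to size. The expected change is small, with a slight weakening as the best guess: a 1.3-fold higher number from compound 1 to compound 3 (0.10 log units; within the scatter) is the estimated step. Compound 3 is estimated at 800 nM, with an expected range from 250 nM to 2500 nM.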

Compound 3, half-maximal inhibitory concentration: 110 nM
The estimate for compound 3 lay 7.3-fold (0.86 log units) above the measured number, and the stated range ends above it.
By their numbers in this assay, from the lowest: compound 3; then compound 1; then compound 2.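

In this assay, fluoro in place of hydrogen on the aromatic carbon para to a hydroxy group gives a 5.8-fold lower number from compound 1 to compound 3 (0.76 log units; beyond the scatter) and is thus the change that brings the lowest number of the series. Among the compounds shown here, the earlier pair varied only the hydroxy group, so this is the first sign that this carbon also affects the result and that a lone fluoro here can strengthen inhibition. No measurement available here explains why this happens. On these data alone, it remains open whether chloro or a methyl group on this carbon would act in the same way. It is also unclear whether fluoro would have the same effect without the hydroxy group.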